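This account rests on a few compounds, and the source may have more. Where it says the series, first, only, none or still open, it means among the compounds named here.

Measured so far:
- compound 1 `CC1=C(C(=O)Nc2ccccc2Cl)C(c2ccc(Br)cc2)NC(=O)N1` — in an ADME assay on Vero cells (Chlorocebus sabaeus) for cytotoxicity, read by XTT assay, with a stated time of 72 h (a higher number here means that more compound is tolerated, a lower number that less compound is tolerated), compound 1 gives > 100000 nM; this is a limit of the assay, not a number.
- compound 2 `COC(=O)C1=C(C)NC(=O)NC1c1ccc(F)cc1` — in this assay compound 2 is recorded as "non-toxic" (no number reported), with no number given.
- compound 3 `COC(=O)C1=C(C)N(C)C(=O)NC1c1ccc(F)cc1` — in this assay compound 3 is recorded as "non-toxic" (no number reported), also with no number given.

Compound 2 therefore has no single number to stand on. Of the three entries in this assay, one further value is a limit and one further entry is a description without a number, so compound 2 can be neither ranked against nor separated from compound 1 or compound 3. The only firm anchor in the set is the limit of > 100000 nM in this assay, at which 1 of the 3 values shown sits.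

Compound 4 `COC(=O)C1=C(C)NC(=O)NC1c1ccc(Br)cc1` differs from compound 2 by bromo in place of fluoro on an aromatic carbon. Among the measured compounds shown here, no measured pair in the set carries this change, so no step size can be read from the data. Compound 1 also carries bromo and sits at the limit, which gives no sign of a shift in either direction. For compound 4 in this assay the expectation is no change beyond the scatter, most likely again a limit or a note without a number. The estimate for compound 4 is 100000 nM, with a range from 40000 nM to 250000 nM.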

Compound 4, half-maximal cytotoxic concentration: 100000 nM
For compound 4 middle estimate and measured number coincide at the digits printed; the range from low to high includes it.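

With bromo in place of fluoro on an aromatic carbon, para to a large group, the series gains its first actual number in this assay. Compound 2 carries only a note, so the size of this change cannot be read, but the bromo compound gives no sign of a low tolerated concentration. On the carbonyl carbon, the step is a number no higher from compound 1 to compound 4 (the limit leaves the size open), with methoxy in place of (2-chlorophenyl)amino, so this exchange gives a direction at most, and the single reference for the series remains: the limit of > 100000 nM in this assay, at which 1 of the 4 values shown sits.

As far as these compounds go, whether an amine, a carboxylic acid or a nitrile on the same aromatic carbon would give a clearly lower number in this assay stays open, as the fluoro and bromo entries do not define how this position responds to a wider change. The difference between compound 2 and compound 3 also stays without a size, since both entries are notes and neither provides a number to compare.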